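Fluorine on the Fused Ring of a Weak Antiproliferative Series

The source may hold more compounds than are shown below. What is called first, only, known or untested is meant among the compounds shown, and "the series" means these compounds.

Compound 1 `Cc1ccc(-c2csc(N3C(=O)c4ccccc4C3=O)n2)cc1`: 38400 nM
Compound 2 `N#Cc1ccc(-c2csc(N3C(=O)c4ccccc4C3=O)n2)cc1`: 40300 nM
Compound 3 `O=C1c2ccc(F)cc2C(=O)N1c1nc(-c2ccccc2)cs1`: 40200 nM

Of the compounds shown here, three sharing one core have been tested in a functional assay on PC-3 cells (Homo sapiens) for antiproliferative activity, read by MTT assay, with a stated time of 48 h; a higher number here means a weaker inhibitor, a lower number a stronger inhibitor. Compound 1 gives 38400 nM, compound 2 gives 40300 nM and compound 3 gives 40200 nM. Compound 2 stands within the usual scatter of both neighbours, so the three numbers cannot be told apart. Going by the values given here, the only single-point step among them, a 1.0-fold higher number from compound 1 to compound 2 (0.02 log units; within the scatter), shows that exchanging the substituent on the pendant phenyl ring leaves the read-out unchanged.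

Compound 4 `N#Cc1ccc(-c2csc(N3C(=O)c4ccc(F)cc4C3=O)n2)cc1` has not yet been measured. It differs from compound 2 by fluoro in place of hydrogen on an aromatic carbon. Among the compounds with values here, no measured step covers this exact change. The nearest evidence is compound 3, which carries the same fluoro on the same fused ring and whose value sits beside those of compounds 1 and 2, separated by nothing beyond the scatter. Nothing in the three numbers suggests that adding fluoro here moves this assay in either direction.

Compound 4 is therefore expected to give 40000 nM, within the range 20000 nM to 80000 nM. The expected step is a 1.0-fold lower number from compound 2 to compound 4 (0.00 log units; within the scatter), that is, none beyond the scatter.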

Compound 4, half-maximal inhibitory concentration: 43100 nM
Estimate against measurement, compound 4: 1.1-fold (0.03 log units) below, within the range that was stated.
By their numbers in this assay, from the lowest: compounds 1, 3, 2 and 4 (each within the scatter of the next).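

In this assay, going by these compounds alone, fluoro in place of hydrogen on an aromatic carbon of the fused system gives a 1.1-fold higher number from compound 2 to compound 4 (0.03 log units; within the scatter) and so supplies the direct single-point step at this position that the earlier compounds lacked, with the nitrile held constant on the pendant phenyl ring. The reverse view of the same compound, with fluoro held constant on the fused system, gives a 1.1-fold higher number from compound 3 to compound 4 (0.03 log units; within the scatter) for adding the nitrile to the pendant phenyl ring, which shows that the nitrile also leaves the read-out unchanged when fluoro is present, a case that compounds 1 and 2 could not cover. No other measurement bears on this flat result, and nothing available can account for it.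

Fluoro is the only group shown on the fused ring, so it remains open whether an amine, a carboxylic acid or a methoxy group on this same carbon would shift the read-out beyond the scatter. The compounds shown also leave open whether any change to the shared core can separate these values at all, since every step printed here stays within the scatter.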